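Adding an amino group to a compound at the limit

The compounds below may be only part of what the source reports. "The series", "measured", "known", "first", "only" and "open" are said of these compounds alone.

Measured in a functional assay on HCT-116 cells (Homo sapiens), read by MTT assay, with a stated time of 72 h; on this read-out higher numbers stand for weaker inhibition and lower numbers for stronger inhibition:
Compound 1 `Cc1ncnc2c1c(-c1cc3ccccc3o1)cn2[C@@H]1O[C@H](CO)[C@@H](O)[C@H]1O` gives > 20000 nM
Compound 2 `O=c1[nH]cnc2c1c(-c1ccccc1)cn2[C@@H]1O[C@H](CO)[C@@H](O)[C@H]1O` gives > 100000 nM
Compound 3 `O=c1[nH]cnc2c1c(-c1cc3ccccc3o1)cn2[C@@H]1O[C@H](CO)[C@@H](O)[C@H]1O` gives > 20000 nM

Compound 3 stands at > 20000 nM in this assay, and this is a limit, not a number. Among the compounds with values here, the other two values are limits as well, as the limit of > 100000 nM in this assay, at which 1 of the 3 values shown sits, and the limit of > 20000 nM in this assay, at which 2 of the 3 values shown sit, record, so no compound here has a true potency to compare.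

Compound 4 `Nc1nc2c(c(-c3cc4ccccc4o3)cn2[C@@H]2O[C@H](CO)[C@@H](O)[C@H]2O)c(=O)[nH]1` differs from compound 3 in one place: amino in place of hydrogen on an aromatic carbon, with the amino group between two ring nitrogen atoms. Within the data shown here, the only measured step, a step that the two limits leave unreadable from compound 2 to compound 3, concerns a different group and cannot be sized, so it offers no guide to this change. With no sign of a gain, no step beyond the scatter is expected in this assay, and the estimated move is a step that the limit leaves unreadable from compound 3 to compound 4 in this case. Compound 4 is estimated at 30000 nM, with an expected range from 8000 nM to 100000 nM, and the assay will most likely report only a limit again.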

Compound 4, half-maximal inhibitory concentration: > 100000 nM
Compound 4: a limit, no number; the forecaster's own chance of this, stated with the estimate: 85%; middle value at least 3.3-fold (0.52 log units) away from the limit.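

In this assay compound 3 gives > 20000 nM, which is a limit and not a number. Within the data shown here, compound 4 gives > 100000 nM, also a limit, so no step between these two compounds can be read. From the compounds shown here alone, whether the amino group changes potency at all remains open.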